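This account rests on a few compounds, and the source may have more. Where it says the series, first, only, none or still open, it means among the compounds named here.

Within an assay on HEK293 cells for positive allosteric modulation of metabotropic glutamate receptor 3 (Rattus norvegicus), read by thallium flux, with a stated time of 2.5 min (a lower number here means that less compound is needed, a higher number that more compound is needed for the effect), three compounds of the series have numbers so far. Compound 1 `CCCC(=O)c1ccc(OCCCCOc2ccc(F)c(C(=O)O)c2)c(C)c1O` gives 438 nM, compound 2 `Cc1c(OCCCCOc2ccc(C(=O)O)cc2F)ccc(C(=O)CC(C)C)c1O` gives 1420 nM, and compound 3 `Cc1cc(OCCCCOc2ccc(C(=O)CC(C)C)c(O)c2C)ccc1C(=O)O` gives 3910 nM, the highest of the three; its nearest neighbour is compound 2, with compound 1 the furthest away.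

Compound 4 `Cc1c(OCCCCOc2ccc(F)c(C(=O)O)c2)ccc(C(=O)CC(C)C)c1O` follows from compound 3 by the change (3-carboxy-4-fluorophenyl in place of 4-carboxy-3-methylphenyl on an oxygen on a saturated carbon). Among the compounds with values here, the only measured step at this position is a 2.8-fold higher number from compound 2 to compound 3 (0.44 log units; beyond the scatter), which exchanges one carboxyphenyl for another and moves the number beyond the scatter. Within the data shown here, no measured step exchanges the 4-carboxy-3-methylphenyl for the 3-carboxy-4-fluorophenyl directly. Compound 1 carries the same 3-carboxy-4-fluorophenyl as compound 4 but differs from it elsewhere in the shared core, so its value only shows that this group is compatible with the lowest number seen. Taken together, a lower number than that of compound 3 is expected for compound 4, and the step is estimated as a 3.9-fold lower number from compound 3 to compound 4 (0.59 log units; beyond the scatter). For compound 4 the estimate in this assay is 1000 nM, with a range from 350 nM to 3000 nM.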

Compound 4, half-maximal effective concentration: 920 nM
Compound 4: middle estimate off by 1.1-fold (0.04 log units), on the high side, and the stated range covers the measured number.
By their numbers in this assay, from the lowest: compound 1; then compounds 4 and 2 (each within the scatter of the next); then compound 3.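

In this assay, within the data shown here, the 3-carboxy-4-fluorophenyl in place of the 4-carboxy-3-methylphenyl gives a 4.3-fold lower number from compound 3 to compound 4 (0.63 log units; beyond the scatter), the first measured step to this group at this position. The exchange of the 4-carboxy-2-fluorophenyl for the same group gives a 1.5-fold lower number from compound 2 to compound 4 (0.19 log units; within the scatter), so the two fluorinated carboxyphenyl groups are not separated here, while the 4-carboxy-3-methylphenyl stands apart from both. With the 3-carboxy-4-fluorophenyl held fixed, methyl in place of hydrogen on the saturated chain carbon gives a 2.1-fold higher number from compound 1 to compound 4 (0.32 log units; beyond the scatter), the first single-place reading away from this position, and a modest one.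

From the compounds shown here alone, whether that methyl step holds with the other carboxyphenyl groups stays open, as does the effect of chlorine in place of the fluorine or a primary amide in place of the carboxylic acid. No measured data offer a reason for any of these steps.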